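Chloro to cyano in the cyclopropylpropyl series

The compounds below may be only part of what the source reports. "The series", "measured", "known", "first", "only" and "open" are said of these compounds alone.

- compound 1 `COC[C@@H](C1CC1)n1cc(Cl)nc(Nc2cc(C)c(OC)nc2C)c1=O`: 13%
- compound 2 `CC[C@H](C1CC1)n1cc(Cl)nc(Nc2cc(C)c(OC)nc2C)c1=O`: 5%
- compound 3 `COC[C@@H](C)n1cc(Cl)nc(Nc2cc(C)c(OC)nc2C)c1=O`: 8%

In an ADME assay on microsomes from liver (Rattus norvegicus) for metabolic stability, read by HPLC, with a stated time of 10 min, tested at 3 uM (a lower number here means that less of the compound is left, a higher number that more of the compound is left), compound 2 gives 5%. Its gaps to the other two values are a number 3 percentage points higher from compound 2 to compound 3 (within the scatter) and a number 8 percentage points lower from compound 1 to compound 2 (within the scatter), so the three measured compounds cannot be ranked on these numbers.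

The next structure is compound 4 `CC[C@H](C1CC1)n1cc(C#N)nc(Nc2cc(C)c(OC)nc2C)c1=O`, which carries one change relative to compound 2: cyano in place of chloro on an aromatic carbon.

For the measured compounds named here, no measured step covers this replacement. All three measured compounds carry chloro, and their steps change only the group on the aromatic nitrogen. Those steps are a number 8 percentage points lower from compound 1 to compound 2 (within the scatter), a number 5 percentage points lower from compound 1 to compound 3 (within the scatter) and a number 3 percentage points higher from compound 2 to compound 3 (within the scatter). They bear on the question only indirectly, showing that this assay stayed within the scatter across these changes elsewhere in the structure. Going by the values given here, with no direct precedent, no step beyond the scatter is expected, and any expected direction is weakly upward, as compound 2 at 5% leaves little room for a fall.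

The expected step is a number 4 percentage points higher from compound 2 to compound 4 (within the scatter).

For compound 4 the estimated value is 9%, with an expected range from 2% to 22%.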

Compound 4, percent of the compound remaining: 38%
The estimate for compound 4 lay 29 percentage points below the measured number, and the stated range ends below it.
By their numbers in this assay, from the lowest: compounds 2, 3 and 1 (each within the scatter of the next); then compound 4.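

For the compounds shown here, the aromatic carbon that carries chloro in compounds 1, 2 and 3 is the first place in this short series where a single change moves this assay beyond the scatter: cyano in place of chloro gives a number 33 percentage points higher from compound 2 to compound 4 (beyond the scatter) and lifts compound 4 clear of all three chloro compounds. The earlier steps all changed the group on the aromatic nitrogen and stayed within the scatter, for example a number 8 percentage points lower from compound 1 to compound 2 (within the scatter) and a number 5 percentage points lower from compound 1 to compound 3 (within the scatter), so among these four compounds only the exchange on the aromatic carbon separates one compound from the rest in this assay. Nothing measured on these compounds accounts for the size of this step.

Still open, as far as these compounds go, is whether the same exchange gives a step of similar size when the aromatic nitrogen carries 1-cyclopropyl-2-methoxyethyl or 1-(methoxymethyl)ethyl instead of 1-cyclopropylpropyl, as the cyano result rests on a single pair. Also open, from the compounds shown here alone, is how other groups on this aromatic carbon, such as fluoro, methyl, trifluoromethyl or a primary amide, would compare with cyano and chloro in this assay.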